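A few compounds are considered here, and "the series" means these few. Any claim that something is new, unique, unknown or untested is made for them only; others in the source may bear on it.

Series notes. For the measured compounds named here, compound 1 `CCOC(=O)C(=O)Nc1cccccc1=O` is the simpler of the two compounds measured so far; in a functional assay on the whole organism (strain Sprague-Dawley CD) for inhibition, with Rattus norvegicus as the target, read by paw edema, at a dose of 30 mg/kg by the intraperitoneal route (on this read-out lower numbers stand for a weaker effect and higher numbers for a stronger effect at the one dose given), compound 1 gives 84%. Compound 2 `CCOC(=O)C(=O)Nc1ccccc(Oc2ccccc2)c1=O` carries phenoxy in place of hydrogen on an aromatic carbon, and in this assay compound 2 gives 16%. Going by the values given here, the single measured step is a number 68 percentage points lower from compound 1 to compound 2 (beyond the scatter). Among the compounds with values here, on the numbers in hand compound 2 therefore stands lowest of the two, with compound 1 as its only neighbour, higher by that same step.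

Compound 3 `CCOC(=O)C(=O)Nc1ccccc(C)c1=O` is not yet measured. Its change from compound 2 is methyl in place of phenoxy on an aromatic carbon. Within the data shown here, the one measured step that bears on this change is the step from compound 1 to compound 2, in which phenoxy entered; here phenoxy leaves and methyl enters, so the change partly undoes that step. Among the measured compounds shown here, because a number 68 percentage points lower from compound 1 to compound 2 (beyond the scatter) was large, the loss of phenoxy is expected to move the read-out in this assay upward by a sizeable amount, although methyl is not hydrogen and no methyl analogue has been measured. The expected step is a number 39 percentage points higher from compound 2 to compound 3 (beyond the scatter). Compound 3 is thus estimated at 55%, with a range from 25% to 85%.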

Compound 3, a percentage reported as inhibition, in the whole organism at one dose (the size of the read-out at that dose, not a potency): 60%
Estimate against measurement, compound 3: 5 percentage points below, within the range that was stated.
By their numbers in this assay, from the lowest: compound 2; then compound 3; then compound 1.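

In this assay, the new result shows that this place on the seven-membered aromatic ring does not reject every substituent: a number 44 percentage points higher from compound 2 to compound 3 (beyond the scatter), so the low read-out of the phenoxy compound belongs to phenoxy and not to substitution as such. Substitution here is still not free, since even methyl in place of hydrogen gives a modest loss, a number 24 percentage points lower from compound 1 to compound 3 (beyond the scatter), which the single earlier step could not show. Across these three compounds the read-out falls in the order hydrogen, methyl, phenoxy, an order that no compound here goes against, and nothing measured so far accounts for it.

Three compounds at one dose leave open whether the fall follows the size of the group or something particular to the phenoxy ring or its oxygen, and they give no potency. A methoxy group or an ethyl chain at this same place would separate these readings, and an amine would show how a group carrying hydrogen-bond donors fares here.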